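The source may hold more compounds than are shown below. What is called first, only, known or untested is meant among the compounds shown, and "the series" means these compounds.

The study concerns two measured compounds and one that awaits measurement in a functional assay on MCF7 cells (Homo sapiens) for cytotoxicity; a lower number here means that less compound is needed, a higher number that more compound is needed for the effect. Compound 1, `CCC(CO)CCn1c(Cc2cc(OC)c(OC)c(OC)c2)nc2c(N)ncnc21`, gives 19200000 nM in this assay. Among the compounds with values here, compound 2, `CCCCn1c(Cc2cc(OC)c(OC)c(OC)c2)nc2c(N)nc(F)nc21`, gives 185000000 nM, the higher of the two numbers; the gap to compound 1 lies beyond the usual scatter, so compound 2 is the one of the pair that needs more material for the effect. Within the data shown here, no single-place step between these two compounds is recorded, so their values are compared only as they stand.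

Compound 3, `CC#CCCn1c(Cc2cc(OC)c(OC)c(OC)c2)nc2c(N)nc(F)nc21`, has not yet been measured. It differs from compound 2 in one place: prop-1-yn-1-yl in place of ethyl on a saturated chain carbon, two bonds along the chain from an aromatic nitrogen. Among the measured compounds shown here, no measured step of this kind exists among the compounds. Since the change brings in a triple bond outside aromatic rings and alters neither hydrogen-bond donors nor acceptors, only a modest step is expected, with no firm direction beyond the scatter, if anything a slight move toward a lower number. Compound 3 is therefore expected to give about 120000000 nM, within a range from 30000000 nM to 500000000 nM. The expected step is a 1.5-fold lower number from compound 2 to compound 3 (0.19 log units; within the scatter).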

Compound 3, half-maximal effective concentration: 95500000 nM
Compound 3: the middle estimate sits 1.3-fold (0.10 log units) above what was measured; low and high end bracket the measured number.
By their numbers in this assay, from the lowest: compound 1; then compounds 3 and 2 (each within the scatter of the next).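

Within the data shown here, at this place on the chain, the exchange of ethyl for prop-1-yn-1-yl, which can also be read as butyl to pent-3-yn-1-yl, gives in this assay a 1.9-fold lower number from compound 2 to compound 3 (0.29 log units; within the scatter), and this is the first one-place comparison available. The change brings in a triple bond outside aromatic rings and leaves the counts of hydrogen-bond donors and acceptors as they were, yet the values of the two compounds cannot be told apart, so this exchange at this place produces no step beyond the scatter. Nothing available speaks to the reason for this outcome.

The compounds shown leave open whether a group of another kind at this place, such as an amine, a carboxylic acid or a longer chain, would produce a step beyond the scatter in this assay. They also leave open whether the same exchange of ethyl for prop-1-yn-1-yl would read the same way on the core of compound 1.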